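Extending the Acrylamide Warhead on a Pyrimidine Anilide

This account rests on a few compounds, and the source may have more. Where it says the series, first, only, none or still open, it means among the compounds named here.

Measured compounds:
- compound 1, `C=CC(=O)Nc1cccc(Nc2nc(N/N=C/c3ccc(F)cc3F)ncc2Cl)c1`: 4760 nM
- compound 2, `C=CC(=O)Nc1cccc(Nc2nc(N/N=C/c3cn(Cc4ccccc4)c4ccccc34)ncc2Cl)c1`: 11000 nM

In an ADME assay on HT-29 cells (Homo sapiens) for inhibition, read by MTT assay, with a stated time of 72 h (a higher number here means a weaker inhibitor, a lower number a stronger inhibitor), compound 2 gives 11000 nM, the higher of the two numbers, and thus the weaker inhibitor of the pair. Compound 1, which carries a different group on the hydrazone, gives 4760 nM in this assay, a difference that lies beyond the usual scatter. Compound 3, `CN(C)C/C=C/C(=O)Nc1cccc(Nc2nc(N/N=C/c3cn(Cc4ccccc4)c4ccccc34)ncc2Cl)c1`, keeps the whole of compound 2 apart from one change: 3-(dimethylamino)prop-1-en-1-yl in place of vinyl on a carbonyl carbon. For the measured compounds named here, no comparable step between measured compounds is available, so the direction of the step rests on general expectation only. A modest move toward a lower number, or none beyond the scatter, is expected for compound 3, with the step from compound 2 estimated as a 1.6-fold lower number from compound 2 to compound 3 (0.20 log units; within the scatter). Compound 3 is therefore expected to give about 7000 nM in this assay, within a range of 2000 nM to 25000 nM.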

Compound 3, half-maximal inhibitory concentration: 2120 nM
For compound 3 the middle estimate is 3.3-fold (0.52 log units) above the measured one, within the range that was stated.
By their numbers in this assay, from the lowest: compound 3; then compound 1; then compound 2.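

In this assay the exchange of vinyl for 3-(dimethylamino)prop-1-en-1-yl on a carbonyl carbon gives a 5.2-fold lower number from compound 2 to compound 3 (0.72 log units; beyond the scatter) and this is the first pair shown that differs in one place. It shows that this position tolerates a larger group ending in an amine, and that the change strengthens inhibition in these cells rather than merely being accepted. Nothing shown here explains why the number falls.

The compounds shown do not separate the contribution of the dimethylamino nitrogen from that of the longer chain, which a plain alkyl chain without an amine would address. Also open, as far as these compounds go, are how a morpholine or piperidine at the chain end would read, and whether the same change would lower the number on compound 1.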